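The compounds below may be only part of what the source reports. "The series", "measured", "known", "first", "only" and "open" are said of these compounds alone.

Measured compounds in an assay on isolated protein for inhibition of alpha-mannosidase (Canavalia ensiformis), tested at 1000 uM; on this read-out lower numbers stand for less inhibition and higher numbers for more inhibition at the one concentration tested (going by the name of the read-out):
compound 1 `OC[C@@]1(c2ccc(F)cc2)NC[C@@H](O)[C@@H]1O` gives 6.6%
compound 2 `OC[C@]1(c2ccc(F)cc2)NC[C@H](O)[C@H]1O` gives 6.6%
compound 3 `COc1cccc([C@]2(CO)NC[C@@H](O)[C@@H]2O)c1` gives 0%

All three numbers sit at the low end of this assay. For the measured compounds named here, compound 1 and compound 2 are level at the digits read, and compound 3 lies within the scatter of both; no compound can be ranked against another here.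

Going by the values given here, the only single-place step available is no change at the digits printed from compound 1 to compound 2 (within the scatter), which rests on the fact that compounds 1 and 2 differ only in the configuration as drawn: a full inversion of every stereocentre leaves the reading untouched. Compound 3 differs from compound 1 in more than one place, so its value is noted only as a second low reading on the same core.

Compound 4 `OC[C@@]1(c2ccc(O)cc2)NC[C@@H](O)[C@@H]1O` is the next entry: hydroxy in place of fluoro on an aromatic carbon. Among the compounds with values here, no measured step addresses a change on the aromatic ring, and the one step that exists shows no movement beyond the scatter. With every reading so far near the floor of this assay, no step beyond the scatter is expected in this assay from compound 1 to compound 4, in either direction; a number 0.4 percentage points higher from compound 1 to compound 4 (within the scatter) is the expected size.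

For compound 4 the estimate in this assay is 7%, with a range from 0% to 20%.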

Compound 4, a percentage reported as inhibition, at one concentration (the size of the read-out at that concentration, not a potency): 2.2%
Compound 4: middle estimate off by 4.8 percentage points, on the high side; measured number inside the range.
By their numbers in this assay, from the lowest: compounds 3, 4, 1 and 2 (each within the scatter of the next).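

In this assay, for the compounds shown here, hydroxy in place of fluoro on an aromatic carbon gives a number 4.4 percentage points lower from compound 1 to compound 4 (within the scatter), the first reading of a change on the aromatic ring rather than in configuration. At this place, para to a group of 9 heavy atoms, the exchange brings in a hydrogen-bond donor and a hydrogen-bond acceptor, yet compound 4 at 2.2% stays at the low end of the assay, so this change separates nothing from the fluoro parent at the one concentration tested. Going by these compounds alone, the only evidence at hand concerns configuration and has no bearing on this change on the ring.

The compounds shown leave open whether an amine, a carboxylic acid or a longer chain on this same aromatic carbon would move the reading beyond the scatter, since fluoro and hydroxy alone can be compared here. They also leave open whether the mirror image of compound 4 would read the same as compound 4, as the only comparison of mirror images shown rests on the fluoro pair, compound 1 and compound 2.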